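Swapping a Cyclopropylamine for a Methoxypiperidine: Clearance Outlook

The compounds below may be only part of what the source reports. "The series", "measured", "known", "first", "only" and "open" are said of these compounds alone.

Compound 1 `CN(c1cc(OCc2cc(F)c(Oc3ccc(Cl)c(C(F)(F)F)c3)c(F)c2)nc(=O)n1C)C1CC1` is the starting point. In an ADME assay on S9 fraction from liver (Rattus norvegicus, strain Wistar) for metabolic stability, tested at 0.1 uM (on this read-out lower numbers stand for slow clearance and higher numbers for fast clearance), compound 1 gives 123 mL/min/kg, the highest number among the three measured compounds. Compound 2 `CCOC(=O)CN(C)c1cc(OCc2cc(F)c(Oc3ccc(Cl)c(C(F)(F)F)c3)c(F)c2)nc(=O)n1C` gives 13.8 mL/min/kg, and compound 3 `Cn1c(N2CCCCC2)cc(OCc2cc(F)c(Oc3ccc(Cl)c(C(F)(F)F)c3)c(F)c2)nc1=O` gives 21.8 mL/min/kg. Compound 4 `COC1CCN(c2cc(OCc3cc(F)c(Oc4ccc(Cl)c(C(F)(F)F)c4)c(F)c3)nc(=O)n2C)CC1` has not yet been measured; it differs from compound 1 in a single place: 4-methoxypiperidin-1-yl in place of cyclopropyl(methyl)amino on an aromatic carbon. The step that bears most closely on this change is a 5.6-fold lower number from compound 1 to compound 3 (0.75 log units; beyond the scatter), since compound 3 also carries a piperidin-1-yl group in that place. The step of an 8.9-fold lower number from compound 1 to compound 2 (0.95 log units; beyond the scatter) points in the same direction. A step of similar size is therefore expected, a 4.9-fold lower number from compound 1 to compound 4 (0.69 log units; beyond the scatter). The estimate for compound 4 is 25 mL/min/kg, with a range from 10 mL/min/kg to 60 mL/min/kg.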

Compound 4, clearance: 184 mL/min/kg
Compound 4: the middle estimate sits 7.4-fold (0.87 log units) below what was measured; measured number outside the range, above it.
By their numbers in this assay, from the lowest: compounds 2 and 3 (each within the scatter of the next); then compounds 1 and 4 (each within the scatter of the next).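

In this assay the methoxy group matters at this position: placing it on the saturated ring of compound 3 gives an 8.4-fold higher number from compound 3 to compound 4 (0.93 log units; beyond the scatter) and shows that a piperidine here does not guarantee a low clearance number. Compound 4 also stands well apart from the ester-bearing compound 2 with a 13-fold higher number from compound 2 to compound 4 (1.12 log units; beyond the scatter) while a 1.5-fold higher number from compound 1 to compound 4 (0.17 log units; within the scatter) means that this swap brings no real change from the starting point. No measured evidence explains this effect of the methoxy group. On these data alone, whether a hydroxy group, a fluorine or an ethoxy group in place of the methoxy would give a similar number stays open.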